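The source may hold more compounds than are shown below. What is called first, only, known or untested is meant among the compounds shown, and "the series" means these compounds.

In a functional assay on HL-60 cells (Homo sapiens) for inhibition, with a stated time of 72 h (on this read-out higher numbers stand for weaker inhibition and lower numbers for stronger inhibition), compound 1 (`[N-]=[N+]=NCc1ncnc2c1ncn2[C@@H]1O[C@H](CO)[C@@H](O)[C@H]1O`) gives 1880 nM, compound 2 (`OC[C@H]1O[C@@H](n2cnc3c(Cn4ccc5ccccc54)ncnc32)[C@H](O)[C@@H]1O`) gives 5700 nM, and compound 3 (`OC[C@H]1O[C@@H](n2cnc3c(COc4ccccn4)ncnc32)[C@H](O)[C@@H]1O`) gives 12000 nM, the highest of the three numbers and so the weakest inhibition. Compound 4 (`CSCc1ncnc2c1ncn2[C@@H]1O[C@H](CO)[C@@H](O)[C@H]1O`) has methylsulfanyl in place of (pyridin-2-yl)oxy on a saturated chain carbon bound to an aromatic carbon. Three measured steps change this same place: a 3.0-fold higher number from compound 1 to compound 2 (0.48 log units; beyond the scatter), a 6.4-fold higher number from compound 1 to compound 3 (0.81 log units; beyond the scatter) and a 2.1-fold higher number from compound 2 to compound 3 (0.32 log units; beyond the scatter), all modest but beyond the scatter. Compound 1, the only one of the three whose group has no ring, is the closest guide, so a modest step to a lower number is expected. The estimated change is a 3.4-fold lower number from compound 3 to compound 4 (0.54 log units; beyond the scatter). For compound 4, the expected value is 3500 nM, with an estimated range of 1000 nM to 11000 nM.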

Compound 4, half-maximal inhibitory concentration: 13400 nM
For compound 4 the middle estimate is 3.8-fold (0.58 log units) below the measured one; measured number above the stated range.
By their numbers in this assay, from the lowest: compound 1; then compound 2; then compounds 3 and 4 (each within the scatter of the next).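

In this assay, a group without a ring did not by itself bring the number down: methylsulfanyl, like azido, has no ring, yet the step reads a 7.1-fold higher number from compound 1 to compound 4 (0.85 log units; beyond the scatter). Methylsulfanyl in place of (pyridin-2-yl)oxy gives no distinction, with a 1.1-fold higher number from compound 3 to compound 4 (0.05 log units; within the scatter), while in place of 1H-indol-1-yl it gives a 2.4-fold higher number from compound 2 to compound 4 (0.37 log units; beyond the scatter), so compound 1 keeps the lowest number of the four. Nothing available explains this result. From the compounds shown here alone, whether an amine, a carboxylic acid or a longer chain such as ethylsulfanyl at this place would track azido or methylsulfanyl stays open.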